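The source may hold more compounds than are shown below. What is called first, only, known or untested is meant among the compounds shown, and "the series" means these compounds.

Compound 1 `C=CS(=O)(=O)N1CCN(c2ncnc3sc(-c4ccc(OC)cc4)cc23)CC1`: 28400 nM
Compound 2 `C=CS(=O)(=O)N1CCN(c2ncnc3sc(-c4ccnc(Cl)c4)cc23)CC1`: 30100 nM

In a functional assay on MDA-MB-436 cells (Homo sapiens) for antiproliferative activity, read by MTT assay, with a stated time of 48 h (a lower number here means a stronger inhibitor, a higher number a weaker inhibitor), compound 1 gives 28400 nM. Among the compounds with values here, only one other number stands beside it, and the two cannot be told apart: a 1.1-fold higher number from compound 1 to compound 2 (0.03 log units; within the scatter). Compound 3 `C=CS(=O)(=O)N1CCN(c2ncnc3sc(-c4ccc(F)nc4)cc23)CC1` has not been measured yet. It differs from compound 1 by a single change: 6-fluoropyridin-3-yl in place of 4-methoxyphenyl on an aromatic carbon. In words, 6-fluoropyridin-3-yl takes the place of 4-methoxyphenyl on an aromatic carbon. Within the data shown here, one measured step bears on this, since it replaces the same 4-methoxyphenyl with 2-chloropyridin-4-yl. There, compound 2 gives 30100 nM, within the scatter of compound 1. Among the measured compounds shown here, a single step is thin evidence, and no measured compound carries the 6-fluoropyridin-3-yl group. Even so, no shift beyond the scatter, in either direction, is expected in this assay. Compound 3 is estimated at 29000 nM, with an expected range of 13000 nM to 60000 nM. This estimate corresponds to an expected 1.0-fold higher number from compound 1 to compound 3 (0.01 log units; within the scatter).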

Compound 3, half-maximal inhibitory concentration: 17500 nM
Compound 3: middle estimate off by 1.7-fold (0.22 log units), on the high side; the measured number falls inside the stated range.
By their numbers in this assay, from the lowest: compounds 3, 1 and 2 (each within the scatter of the next).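

In this assay, the carbon next to the ring sulfur now has a second measured replacement for 4-methoxyphenyl, with a 1.6-fold lower number from compound 1 to compound 3 (0.21 log units; within the scatter), and the two pyridinyl groups can also be compared directly, with a 1.7-fold lower number from compound 2 to compound 3 (0.24 log units; within the scatter). Three different six-membered aromatic rings therefore sit at this position with no difference beyond the scatter, whether the ring holds only carbon or a hetero atom, and whether the halogen is chlorine or fluorine. No measurement is available to explain this result.

As far as these compounds go, all three groups are aromatic rings, so it remains open how this position would respond to an amine, a carboxylic acid or a longer chain. Also open, from the compounds shown here alone, is whether a change elsewhere on the shared core would move the number beyond the scatter.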